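Stereo-defined linker variant of compound 1 in the series

The source may report more compounds than this note shows. Statements on the series, on what has been measured and on what is new or still open speak of the compounds shown alone.

The reference point is compound 1 `CCCN(CCC/C=C\c1ccc(O)c(OC)c1)C1CCc2nc(N)sc2C1`. In an assay on HEK293 cells for displacement of a labelled ligand from D(3) dopamine receptor (Rattus norvegicus), with a stated time of 1 h (on this read-out higher numbers stand for weaker inhibition and lower numbers for stronger inhibition), compound 1 gives 23.3 nM, the highest number among the three measured compounds. Compound 3 `CCCN(CCCc1ccc(O)c(O)c1)C1CCc2nc(N)sc2C1`, with the shortest linker of the set, gives 11.9 nM in this assay, a number that lies within the usual scatter of that for compound 1, so no order between the two is claimed. Compound 2 `CCCN(CCCCCCc1ccc(O)c(OC)c1)C1CCc2nc(N)sc2C1`, carrying a saturated six-carbon linker, gives 0.675 nM in this assay, a number well below that of compound 1 and beyond the scatter, so among these three only compound 2 stands apart from compound 1.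

The compound now in question is compound 4 `CCCN(CCC/C=C/c1ccc(O)c(OC)c1)[C@H]1CCc2nc(N)sc2C1`. Its difference from compound 1 is confined to stereo elements: the two compounds have the same atoms and bonds; at least one stereo element is drawn with a configuration in one of them and without one in the other: 2 of 2 stereo elements differ; a stereocentre at a saturated ring carbon is drawn without a configuration in compound 1 and S in compound 4; a double bond is drawn Z in compound 1 and E in compound 4 No atoms or bonds leave or enter. Within the data shown here, no measured pair in the set separates two stereo drawings of the same constitution, so there is no precedent here for the size of such a step; a movement to a lower number in this assay is expected, though a result within the scatter of compound 1 cannot be excluded. The step from compound 1 to compound 4 is thus estimated as a 2.9-fold lower number from compound 1 to compound 4 (0.46 log units; beyond the scatter). For compound 4 the expected inhibition constant in this assay is 8 nM, with a range from 2 nM to 30 nM.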

Compound 4, inhibition constant: 22.3 nM
Compound 4: middle estimate off by 2.8-fold (0.45 log units), on the low side; the range from low to high includes it.
By their numbers in this assay, from the lowest: compound 2; then compounds 3, 4 and 1 (each within the scatter of the next).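

Among these compounds, this is the first step that separates two stereo drawings of one constitution. In this assay, the double bond drawn E instead of Z, together with the stereocentre at the saturated ring carbon drawn S instead of without a configuration, gives a 1.0-fold lower number from compound 1 to compound 4 (0.02 log units; within the scatter). The step therefore gives no sign that the two stereo elements, changed together in this unsaturated linker, matter to this read-out, but it is not a clean measure of the S configuration because of how the pair is drawn: the fact that one of compounds 1 and 4 is drawn with a defined configuration and the other without, at the place where they differ

Still open is what each stereo element does alone, since two separate effects that cancel would look the same in this single step, and the R configuration at the saturated ring carbon with an E double bond is a further case that the compounds shown do not cover. Also open, from the compounds shown here alone, is whether a linker carrying an amide in place of the double bond would give a number within the scatter of compound 1 and compound 4.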